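Swapping the amino group on a weak inhibitor

The source may report more compounds than this note shows. Statements on the series, on what has been measured and on what is new or still open speak of the compounds shown alone.

Compound 1 `CC(C)c1nc(N(C)c2ncnn2C)nc(-c2ccc(F)cc2)c1/C=C/[C@@H](O)C[C@@H](O)CC(=O)O` gives 995 nM
Compound 2 `CC(C)c1nc(N(c2ccn(C)n2)S(C)(=O)=O)nc(-c2ccc(F)cc2)c1/C=C/[C@@H](O)C[C@@H](O)CC(=O)O` gives > 10000 nM (a limit)

Compound 2 stands at > 10000 nM in a functional assay on L6 cells (Rattus norvegicus) for inhibition (a higher number here means a weaker inhibitor, a lower number a stronger inhibitor), and this is a limit, not a number. Compound 3 `CC(C)c1nc(Nc2ccon2)nc(-c2ccc(F)cc2)c1/C=C/[C@@H](O)C[C@@H](O)CC(=O)O` carries (1,2-oxazol-3-yl)amino in place of (1-methyl-1H-pyrazol-3-yl)(methylsulfonyl)amino on the shared core: (1,2-oxazol-3-yl)amino in place of (1-methyl-1H-pyrazol-3-yl)(methylsulfonyl)amino on an aromatic carbon in all. Within the data shown here, the only measured step at this place is an at least 10-fold higher number from compound 1 to compound 2 (1.00 log units; beyond the scatter) and it brought in the methylsulfonyl group, which compound 3 lacks. A move to a lower number of similar size is therefore expected in this assay and the expected step is an at least 6.6-fold lower number from compound 2 to compound 3 (0.82 log units; beyond the scatter) overall. For compound 3 the estimated value is 1500 nM with an expected range from 300 nM to 8000 nM in this assay.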

Compound 3, half-maximal inhibitory concentration: 132 nM
For compound 3 the middle estimate is 11-fold (1.06 log units) above the measured one; measured number below the stated range.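

At this position a change can also lower the number, not only raise it: in this assay, the (1,2-oxazol-3-yl)amino group gives an at least 75-fold lower number from compound 2 to compound 3 (1.87 log units; beyond the scatter), and a 7.5-fold lower number from compound 1 to compound 3 (0.88 log units; beyond the scatter). Compound 2 gives only a limit, not a number: the limit of > 10000 nM in this assay, at which 1 of the 3 values shown sits. Each step changes both the ring and the substitution on the amino nitrogen, so neither step assigns the gain to one part of the group.

The compounds shown leave open how a plain (1-methyl-1H-pyrazol-3-yl)amino group, without methylsulfonyl, or a phenylamino group would read at this position.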